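A few compounds are considered here, and "the series" means these few. Any claim that something is new, unique, unknown or untested is made for them only; others in the source may bear on it.

Measured compounds:
- compound 1 `Cc1cnc(Nc2ccc(C(C)C)cc2)nc1Nc1nc2ccccc2s1`: > 50000 nM in a functional assay on HCT-116 cells (Homo sapiens) for antiproliferative activity, read by MTT assay, with a stated time of 48 h; a higher number here means a weaker inhibitor, a lower number a stronger inhibitor
- compound 2 `CS(=O)(=O)c1ccc(Nc2ncc(F)c(Nc3nc4ccc(Cl)cc4s3)n2)cc1`: 20700 nM in this assay

Compound 1 stands at the top of the range shown: its result in this assay is a limit of the assay, not a number, and the same is true of the limit of > 50000 nM in this assay, at which 1 of the 2 values shown sits. For compound 2 the assay returned a number, and compound 2 gives 20700 nM in this assay; compound 1 and compound 2 differ in more than one place, so their two values are simply set side by side here.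

Compound 3 `Cc1cnc(Nc2cccc(F)c2)nc1Nc1nc2ccccc2s1` is not yet measured. It differs from compound 1 in one place: 3-fluorophenyl in place of 4-isopropylphenyl on a nitrogen on an aromatic ring, the other neighbour of that nitrogen being an aromatic carbon. No step between measured compounds tells what such a change does in this assay; nothing among the shown values points to a move beyond the scatter in either direction.

Expectation: compound 3 is estimated at 50000 nM (range 15000 nM to 150000 nM) in this assay, the step from compound 1 to compound 3 being expected as a number no higher from compound 1 to compound 3 (the limit leaves the size open), with a real chance that the assay again reports only a limit.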

Compound 3, half-maximal inhibitory concentration: 27800 nM
Compound 3: middle estimate off by 1.8-fold (0.25 log units), on the high side, within the range that was stated.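

In this assay, 3-fluorophenyl in place of 4-isopropylphenyl on a nitrogen on an aromatic ring gives an at least 1.7-fold lower number from compound 1 to compound 3 (0.25 log units; that floor lies within the scatter), the first step read at this position, and only its floor is known. The result of compound 1, > 50000 nM, is a limit of the assay and not a number, so the true size of the step stays open: the limit of > 50000 nM in this assay, at which 1 of the 3 values shown sits.

Compound 3 gives 27800 nM, which supplies a measured number for this core with an aryl group at this position. The step does not establish a change beyond the usual scatter.

For the compounds shown here, the single step replaces one whole aryl group with another, so it does not separate the loss of the isopropyl group from the arrival of the fluorine, or show how the place of either on the phenyl ring bears on the result. Also open, going by these compounds, is how this assay responds to an unsubstituted phenyl, or to a phenyl carrying a carboxylic acid or a primary amine, on this nitrogen while the rest of compound 3 stays unchanged.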